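The compounds below may be only part of what the source reports. "The series", "measured", "known", "first", "only" and "open" are said of these compounds alone.

Measured so far:
Compound 1 `Cc1cccc(C2CC(c3ccc(Oc4ccccc4)cc3)=NN2c2ccc(S(N)(=O)=O)cc2)c1`: in an ADME assay on BHK-21 cells (Mesocricetus auratus) for cytotoxicity, read by MTT assay, with a stated time of 72 h (a higher number here means that more compound is tolerated, a lower number that less compound is tolerated), compound 1 gives 8000 nM.
Compound 2 `NS(=O)(=O)c1ccc(N2N=C(c3ccc(OCc4ccccc4)cc3)CC2c2ccc(F)cc2)cc1`: in this assay compound 2 gives 60000 nM.

Of these two numbers, compound 2 stands highest, so it is the better-tolerated one. Compound 3 `NS(=O)(=O)c1ccc(N2N=C(c3ccc(Oc4ccccc4)cc3)CC2c2ccc(F)cc2)cc1` has not been measured yet. It differs from compound 2 in one place only: phenyl in place of benzyl on an oxygen on an aromatic ring. For the measured compounds named here, no measured pair shows this change on its own, so its size is uncertain. Compound 1 shares the phenoxy group with compound 3 and gives the lower number, so a drop beyond the scatter is expected from compound 2 to compound 3, a 3.0-fold lower number from compound 2 to compound 3 (0.48 log units; beyond the scatter). Compound 3 is therefore estimated at 20000 nM, within 6000 nM to 60000 nM.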

Compound 3, half-maximal cytotoxic concentration: 8000 nM
The estimate for compound 3 lay 2.5-fold (0.40 log units) above the measured number, within the range that was stated.
By their numbers in this assay, from the lowest: compounds 1 and 3 (each within the scatter of the next); then compound 2.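

Phenyl in place of benzyl on the oxygen gives the first direct reading of this position: in this assay there is a 7.5-fold lower number from compound 2 to compound 3 (0.88 log units; beyond the scatter) and less compound is tolerated. At the saturated ring carbon, 4-fluorophenyl in place of 3-methylphenyl gives no change at the digits printed from compound 1 to compound 3 (within the scatter) and so shows no separable effect. Nothing available here explains either result.

Still open, from the compounds shown here alone, is how a longer carbon chain or an amine on this oxygen would compare with phenyl and benzyl. Going by these compounds, whether the benzyl to phenyl step holds with 3-methylphenyl on the saturated ring carbon is also open.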